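Benzimidazolyl replacing pyridinyl on the shared core

The source may hold more compounds than are shown below. What is called first, only, known or untested is meant among the compounds shown, and "the series" means these compounds.

Measured so far:
compound 1 `O=c1[nH]/c(=C\c2ccccn2)c(=O)[nH]/c1=C\c1cccc(Oc2ccc(F)cc2)c1` — 49.1 nM
compound 2 `Cc1ccc(/C=c2\[nH]c(=O)/c(=C/c3cccc(C(=O)c4ccc(F)cc4)c3)[nH]c2=O)o1` — 5.3 nM

In a functional assay on NCI-H460 cells (Homo sapiens) for cytotoxicity, read by MTT assay, with a stated time of 72 h (a lower number here means a stronger inhibitor, a higher number a weaker inhibitor), compound 1 gives 49.1 nM, the highest of the two numbers available. Going by the values given here, compound 2 gives 5.3 nM, a lower number that lies beyond the scatter; the two compounds differ in more than one place, so the values show only that compound 2 is the stronger inhibitor of the pair, without tying that to any single change.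

Compound 3 `O=c1[nH]/c(=C\c2nc3ccccc3[nH]2)c(=O)[nH]/c1=C\c1cccc(Oc2ccc(F)cc2)c1` has not yet been measured. Against compound 1 the change is in one place: 1H-benzimidazol-2-yl in place of pyridin-2-yl on a double-bonded chain carbon bound to an aromatic carbon. Among the compounds with values here, no measured pair shows this change, so the data give no size or direction for it. The step is expected to be a 1.2-fold lower number from compound 1 to compound 3 (0.09 log units; within the scatter), at most modest and not clearly beyond the scatter, with its direction open. On that basis compound 3 is estimated at 40 nM, with a range from 10 nM to 160 nM.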

Compound 3, half-maximal inhibitory concentration: > 1000 nM
Compound 3 ended at the assay's limit; the forecaster's own chance of this, stated with the estimate: 3%; middle value at least 25-fold (1.39 log units) away from the limit.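

In this assay compound 3 gives > 1000 nM, which is a limit of the assay and not a number. This place on the shared core, a double-bonded chain carbon bound to an aromatic carbon, is therefore not indifferent to its group: 1H-benzimidazol-2-yl in place of pyridin-2-yl gives an at least 20-fold higher number from compound 1 to compound 3 (1.30 log units; beyond the scatter). The step sets a bound on the loss of potency and not its full size: the limit of > 1000 nM in this assay, at which 1 of the 3 values shown sits.

On these data alone, whether the loss goes with the added six-membered aromatic ring of carbon only or with the added hydrogen-bond donor stays open, as this one change brings in both. Imidazol-2-yl, without the carbon-only ring, and 1-methylbenzimidazol-2-yl, without the donor, would separate the two.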